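The source may hold more compounds than are shown below. What is called first, only, known or untested is meant among the compounds shown, and "the series" means these compounds.

Compound 1 `CS(=O)(=O)c1ccc(C(=O)Nc2ccc(Cl)c(-c3nnc4c(Cl)cccn34)c2)c(Cl)c1` sets the starting point of this account. In a functional assay on HeLa cells (Homo sapiens) for antiproliferative activity, read by MTT assay, with a stated time of 72 h (on this read-out lower numbers stand for stronger inhibition and higher numbers for weaker inhibition), compound 1 gives > 100000 nM, which is a limit of the assay rather than a number. Two close relatives frame where it stands. Compound 2 `O=C(Nc1ccc(Cl)c(-c2nnc3c(Cl)cccn23)c1)c1ccccc1` gives > 100000 nM in this assay, again a limit and not a number. Compound 3 `Cc1nc(C(=O)Nc2ccc(Cl)c(-c3nnc4c(Cl)cccn34)c2)cs1` gives 79800 nM in this assay. Among the measured compounds shown here, the single measured step, an at least 1.2-fold lower number from compound 2 to compound 3 (0.09 log units; that floor lies within the scatter), lies at the floor of what the assay can show, so two of the three values sit at the limit of > 100000 nM in this assay, at which 2 of the 3 values shown sit, and the third is not far from it.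

Compound 4 `CS(=O)(=O)c1ccc(C(=O)Nc2ccc(Cl)c(-c3nnc4c(Cl)cccn34)c2)cc1` is the next member. It differs from compound 1 by hydrogen in place of chloro on an aromatic carbon. For the measured compounds named here, no measured step concerns this position; the one step recorded changes the group on the carbonyl carbon, and its size fell within the scatter. The numbers give no basis for expecting a change that exceeds the scatter in this assay.

Compound 4 is therefore expected to give about 100000 nM in this assay, within 30000 nM to 300000 nM. The step of a number no higher from compound 1 to compound 4 (the limit leaves the size open) is the expected outcome, and a limit rather than a number is the likelier report.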

Compound 4, half-maximal inhibitory concentration: > 100000 nM
Compound 4 gave a limit, no number; the forecaster's own chance of this, stated with the estimate: 70%; the middle value lies on the limit itself.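

In this assay compound 4 stays at a limit, > 100000 nM, which is not a number, so hydrogen in place of chloro on this aromatic carbon, meta to a methylsulfonyl group, brings no measurable value into view. Among the compounds shown here, the steps joining compound 4 to compound 1 and to compound 2 cannot be read, with a limit at both ends of each, and the only readable step is an at least 1.2-fold higher number from compound 3 to compound 4 (0.09 log units; that floor lies within the scatter), so the 4-(methylsulfonyl)phenyl and 2-methyl-1,3-thiazol-4-yl groups on the carbonyl carbon are not told apart in this assay. The new result adds a further compound with the chloro group absent to the set that reaches the ceiling, and the series remains gathered there: the limit of > 100000 nM in this assay, at which 3 of the 4 values shown sit.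

On these data alone, whether chloro or hydrogen on this carbon makes any difference stays open, as neither compound gives a number to compare. The compounds shown also leave open what an amine or a carboxylic acid in place of the methylsulfonyl group would give, and whether any change to the shared core would bring values clear of the limit.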